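Switching the aryl group: from compound 3 to compound 4

The source may hold more compounds than are shown below. What is called first, only, known or untested is meant among the compounds shown, and "the series" means these compounds.

Compound 3 `COC(=O)C1=C(C)N=C(C)/C(=C(\O)OC)C1c1cccc(Br)c1` gives 1.29 nM in a functional assay (muscle tissue) with Cavia porcellus as the target (a lower number here means that less compound is needed, a higher number that more compound is needed for the effect), the lowest of the three numbers measured. Compound 2 `COC(=O)C1=C(C)N=C(C)/C(=C(\O)OC)C1c1ccccc1C(F)(F)F` gives 1.51 nM in this assay, within the scatter of compound 3. Compound 1 `COC(=O)C1=C(C)N=C(C)/C(=C(\O)OC)C1c1cccc(N(C)C)c1` gives 891 nM in this assay, far above both. Going by the values given here, the only step that changes one place on a measured pair is a 690-fold lower number from compound 1 to compound 3 (2.84 log units; beyond the scatter), which shows that the substituent on the aryl ring can shift the number by a large amount.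

Compound 4 `C=Cc1ccccc1C1C(C(=O)OC)=C(C)N=C(C)/C1=C(\O)OC` is the next analogue. The change is 2-vinylphenyl in place of 3-bromophenyl on a saturated ring carbon. Among the compounds with values here, no measured step matches it. What bears on it is that compound 2 and compound 3, with different substituents on different parts of the aryl ring, sit within the scatter of each other, so a 2-substituted aryl group is compatible with a low number here.

For compound 4 a step of a 2.3-fold higher number from compound 3 to compound 4 (0.37 log units; beyond the scatter) is expected, a small rise that may not exceed the scatter. Compound 4 is estimated at 3 nM in this assay, within 0.5 nM to 20 nM.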

Compound 4, half-maximal effective concentration: 4.47 nM
Compound 4: the middle estimate sits 1.5-fold (0.17 log units) below what was measured; the measured number falls inside the stated range.
By their numbers in this assay, from the lowest: compounds 3 and 2 (each within the scatter of the next); then compound 4; then compound 1.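

In this assay, going by these compounds alone, vinyl in place of trifluoromethyl gives a 3.0-fold higher number from compound 2 to compound 4 (0.47 log units; beyond the scatter) and so supplies the first measured step between two groups on the same aromatic carbon, showing that the number responds modestly to this exchange. 2-vinylphenyl in place of 3-bromophenyl on the saturated ring carbon gives a 3.5-fold higher number from compound 3 to compound 4 (0.54 log units; beyond the scatter) and is therefore also beyond the scatter, yet it is much smaller than a 690-fold lower number from compound 1 to compound 3 (2.84 log units; beyond the scatter) and leaves this all-carbon aryl group with a low number. No accompanying measurement offers an explanation for either step.

On these data alone, whether a longer chain in place of vinyl, or a carboxylic acid on the aryl ring, would keep the number low remains open. Also open, as far as these compounds go, is what vinyl would give on the aromatic carbon that carries bromo in compound 3.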